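Cyclobutyl for Oxolan-3-yl on the Aminoquinoline Ether

This account rests on a few compounds, and the source may have more. Where it says the series, first, only, none or still open, it means among the compounds named here.

Measured so far in an assay on cells with melanin-concentrating hormone receptor 1 (Homo sapiens) as the target, read by radioligand binding; on this read-out higher numbers stand for weaker inhibition and lower numbers for stronger inhibition:
Compound 1, `CCOCC(C)Oc1cccc2ccc(N)nc12`, gives 1070 nM.
Compound 2, `Nc1ccc2cccc(OCC3CCCO3)c2n1`, reaches only the limit > 2000 nM, which is a bound of the assay and not a number.
Compound 3, `Nc1ccc2cccc(OCC3CCOC3)c2n1`, gives 115 nM.

Among the two numbers shown, compound 3 stands lowest; its nearest neighbour is compound 1, reached by a 9.3-fold lower number from compound 1 to compound 3 (0.97 log units; beyond the scatter). The other measured steps are an at least 1.8-fold higher number from compound 1 to compound 2 (0.27 log units; that floor lies within the scatter) and an at least 17-fold lower number from compound 2 to compound 3 (1.24 log units; beyond the scatter), the last one resting on the limit (the limit of > 2000 nM in this assay, at which 1 of the 3 values shown sits).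

Compound 4, `Nc1ccc2cccc(OCC3CCC3)c2n1`, differs from compound 3 by cyclobutyl in place of oxolan-3-yl on a saturated chain carbon bound to an oxygen on an aromatic ring. It keeps a five-membered ring's neighbour, a ring, but the ring is now four-membered and of carbon only, with no hydrogen-bond acceptor. The step from compound 2 to compound 3 shows that the position of the hetero atom in the ring matters strongly, and the step from compound 1 to compound 3 shows that the ring itself helps. Neither step tests removing the hetero atom altogether, so the direction is uncertain; a moderate rise in this assay is expected, as a 3.5-fold higher number from compound 3 to compound 4 (0.54 log units; beyond the scatter). Compound 4 is therefore expected at about 400 nM, within 120 nM to 1500 nM.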

Compound 4, half-maximal inhibitory concentration: 432 nM
The estimate for compound 4 lay 1.1-fold (0.03 log units) below the measured number; low and high end bracket the measured number.
By their numbers in this assay, from the lowest: compound 3; then compound 4; then compound 1. At a limit, above all of these: compound 2.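

In this assay, replacing oxolan-3-yl with the all-carbon cyclobutyl ring costs potency (a 3.8-fold higher number from compound 3 to compound 4 (0.57 log units; beyond the scatter)), yet the result stays ahead of the open-chain ether (a 2.5-fold lower number from compound 1 to compound 4 (0.39 log units; beyond the scatter)), so a ring at this position helps even with no ring oxygen, and oxolan-3-yl adds further to it. Cyclobutyl also comes out ahead of oxolan-2-yl (an at least 4.6-fold lower number from compound 2 to compound 4 (0.66 log units; beyond the scatter)), which shows that an oxygen in the ring is not favourable wherever it sits, and that oxolan-2-yl does worse here than a ring with none. The value of compound 2 in that comparison is a limit of the assay and not a number: the limit of > 2000 nM in this assay, at which 1 of the 4 values shown sits.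

Because the step to cyclobutyl changes ring size and removes the oxygen together, the two contributions remain unseparated. Cyclopentyl would keep the ring size of oxolan-3-yl without the oxygen, and a pyrrolidin-3-yl ring would show whether a ring amine can stand in for that oxygen.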